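The source may hold more compounds than are shown below. What is called first, only, known or untested is meant among the compounds shown, and "the series" means these compounds.

Measured so far in a functional assay on HL-60 cells (Homo sapiens) for antiproliferative activity, read by XTT assay, with a stated time of 72 h (a lower number here means a stronger inhibitor, a higher number a weaker inhibitor), each value being a limit and not a number:

Compound 1 `Cc1ncnc2c1c(-c1cc3ccccc3o1)cn2[C@@H]1O[C@H](CO)[C@@H](O)[C@H]1O`: > 20000 nM
Compound 2 `Nc1nc2c(c(-c3ccco3)cn2[C@@H]2O[C@H](CO)[C@@H](O)[C@H]2O)c(=O)[nH]1`: > 20000 nM
Compound 3 `Nc1nc2c(c(-c3ccoc3)cn2[C@@H]2O[C@H](CO)[C@@H](O)[C@H]2O)c(=O)[nH]1`: > 15000 nM

Compound 3 has no exact value and stands at the limit of > 15000 nM in this assay, at which 1 of the 3 values shown sits. Compound 1 and compound 2 stand at the limit of > 20000 nM in this assay, at which 2 of the 3 values shown sit. None of the three compounds therefore gives a number that could anchor a comparison.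

The next compound is compound 4 `Nc1nc2c(c(-c3cccs3)cn2[C@@H]2O[C@H](CO)[C@@H](O)[C@H]2O)c(=O)[nH]1`, which has thiophen-2-yl in place of furan-3-yl on an aromatic carbon. Going by the values given here, the shared core and the sugar portion stay the same, so only this one group changes.

The closest evidence is the swap of one furan attachment for the other, a step that the two limits leave unreadable from compound 2 to compound 3. Among the compounds with values here, it has no readable size, and no measured step involves a thiophen-2-yl group. Both of its end points are limits, so it offers no direction either. The expectation in this assay is therefore for no step beyond the usual scatter, and most likely for another limit.

The expected change is a step that the limit leaves unreadable from compound 3 to compound 4. Compound 4 is estimated at 20000 nM, with an expected range from 10000 nM to 40000 nM.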

Compound 4, half-maximal inhibitory concentration: > 20000 nM
Compound 4 gave a limit, no number; the forecaster's own chance of this, stated with the estimate: 85%; the middle value sits exactly at the limit.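

In this assay compound 4 gives > 20000 nM, which is a limit and not a number. Going by these compounds alone, no step among compound 2, compound 3 and compound 4 can be read, since all three values are limits. The compounds shown leave open whether furan-2-yl, furan-3-yl and thiophen-2-yl differ at all in this activity.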